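The source may hold more compounds than are shown below. What is called first, only, known or untested is meant among the compounds shown, and "the series" means these compounds.

Of the compounds shown here, three built on the same core have been measured in a functional assay on MCF7 cells (Homo sapiens) for antiproliferative activity, read by MTT assay, with a stated time of 24 h; on this read-out higher numbers stand for weaker inhibition and lower numbers for stronger inhibition. Compound 1 `COC(=O)c1scc(-c2ccc(NC(=O)c3ccc(OC)nc3)cc2)c1OC` gives 5250 nM. Compound 3 `COC(=O)c1scc(-c2ccc(NC(=O)c3ccc(F)c(Cl)n3)cc2)c1OC` gives 10300 nM. Compound 2 `COC(=O)c1scc(-c2ccc(NC(=O)c3cccc(C(F)(F)F)c3)cc2)c1OC` gives 26200 nM, the highest of the three numbers and thus the weakest inhibitor among them: there is a 5.0-fold higher number from compound 1 to compound 2 (0.70 log units; beyond the scatter) and a 2.5-fold lower number from compound 2 to compound 3 (0.41 log units; beyond the scatter), while a 2.0-fold higher number from compound 1 to compound 3 (0.29 log units; within the scatter). Compound 4 `COC(=O)c1scc(-c2ccc(NC(=O)c3cccc(OC(F)(F)F)c3)cc2)c1OC` differs from compound 2 in one place: trifluoromethoxy in place of trifluoromethyl on an aromatic carbon. The ring that carries the group stays the same; only the group on it changes.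

None of the three measured steps bears directly on this change. Each of them exchanges the entire ring on the carbonyl carbon for a different ring, and even those larger exchanges move the numbers only modestly. Data on a trifluoromethyl to trifluoromethoxy swap are absent, so the expectation for compound 4 rests on the small size of every step seen so far. For compound 4 the estimate therefore means a 1.3-fold lower number from compound 2 to compound 4 (0.12 log units; within the scatter), a step inside the usual scatter. In this assay compound 4 is expected to give about 20000 nM, with a range from 7000 nM to 60000 nM.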

Compound 4, half-maximal inhibitory concentration: 2220 nM
Compound 4: the middle estimate sits 9.0-fold (0.95 log units) above what was measured, and the stated range ends above it.
By their numbers in this assay, from the lowest: compound 4; then compounds 1 and 3 (each within the scatter of the next); then compound 2.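

In this assay, exchanging trifluoromethyl for trifluoromethoxy, on an aromatic carbon meta to a large group, gives a 12-fold lower number from compound 2 to compound 4 (1.07 log units; beyond the scatter). Among these compounds, the earlier steps each replaced a whole ring on the carbonyl carbon and were modest or within the scatter, whereas this step keeps the ring and changes only one group, yet it is large, so a small edit at this position can change the read-out substantially. The entering group has 5 heavy atoms against 4 and 1 hydrogen-bond acceptor against 0, but these counts only describe the change, and no measurement here explains why the number falls.

The compounds shown leave open whether the oxygen in the new group matters on its own or only together with the three fluorine atoms, a question that an amine or a longer chain such as ethoxy at the same place would help to answer. They also leave open whether the same exchange would have a comparable effect on a different ring, such as those carried by compound 1 and compound 3.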